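The source may report more compounds than this note shows. Statements on the series, on what has been measured and on what is new or still open speak of the compounds shown alone.

Measured compounds:
- compound 1, `Nc1nccc(-c2cc(OC3CCOC3)c3c(N)n[nH]c3c2)n1`: 751000 nM
- compound 2, `Nc1nccc(-c2ccc3cn[nH]c3c2)n1`: 215000 nM

In a physicochemical assay for solubility, read by LC-MS, in phosphate buffer, measured as kinetic solubility, with a stated time of 24 h, at 25 degrees C, at pH 7.4 (on this read-out lower numbers stand for lower solubility and higher numbers for higher solubility), compound 1 gives 751000 nM, the highest of the two numbers shown. Its nearest neighbour is compound 2, which in this assay gives 215000 nM, a lower number and a gap beyond the usual scatter. For the measured compounds named here, no pair of measured compounds differs in a single place, so no measured step is available to guide the next compound.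

Compound 3, `Nc1nccc(-c2cc(Oc3ccccc3)c3c(N)n[nH]c3c2)n1`, differs from compound 1 in one place: phenyl in place of oxolan-3-yl on an oxygen on an aromatic ring. Going by the values given here, with no measured step of this kind to lean on, the expectation rests on the change alone. The step from compound 1 to compound 3 is expected to be a decrease in this assay, of a size beyond the scatter, a 5.0-fold lower number from compound 1 to compound 3 (0.70 log units; beyond the scatter). Compound 3 is therefore estimated at 150000 nM in this assay, with a range from 40000 nM to 500000 nM.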

Compound 3, solubility: 117000 nM
For compound 3 the middle estimate is 1.3-fold (0.11 log units) above the measured one; the measured number falls inside the stated range.
By their numbers in this assay, from the lowest: compounds 3 and 2 (each within the scatter of the next); then compound 1.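

In this assay, for the compounds shown here, the swap of oxolan-3-yl for phenyl on the oxygen on an aromatic ring gives a 6.4-fold lower number from compound 1 to compound 3 (0.81 log units; beyond the scatter) and is the only measured step in this set, with a size beyond the scatter. Going by these compounds alone, it shows that the read-out at this position responds to the group carried on the oxygen, which the earlier compounds could not show because no two of them differed in one place. No measurement shown here accounts for the drop.

Within the data shown here, the single step also changes several things at once, so it remains open whether the ring oxygen or the aromatic ring goes with the lower number, a question that cyclopentyl and pyridyl on the same oxygen would separate. Also open, going by these compounds, is where an amine, a carboxylic acid or a longer chain at this place would fall relative to compound 1 and compound 3.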